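The source may hold more compounds than are shown below. What is called first, only, known or untested is meant among the compounds shown, and "the series" means these compounds.

Three analogues of a shared core differ only in the group on a saturated chain carbon bound to a saturated ring carbon. Compound 1 `COC(=O)CC1CCN(C[C@H]2CN(c3ccc(-n4cc(-c5ccccn5)cn4)c(F)c3)C(=O)O2)CC1` gives 92100 nM in a physicochemical assay for solubility, read by HPLC, with a stated time of 24 h; a lower number here means a less soluble compound, a higher number a more soluble compound; compound 2 `O=C1CSC(=O)N1C[C@H]1CN(c2ccc(-n3cc(-c4ccccn4)cn3)c(F)c2)C(=O)O1` gives 26900 nM in this assay; compound 3 `O=C1O[C@@H](Cn2ccnn2)CN1c1ccc(-n2cc(-c3ccccn3)cn2)c(F)c1` gives 247000 nM. Compound 3 stands highest of the three measured numbers: a 2.7-fold higher number from compound 1 to compound 3 (0.43 log units; beyond the scatter), a 9.2-fold higher number from compound 2 to compound 3 (0.96 log units; beyond the scatter), while a 3.4-fold lower number from compound 1 to compound 2 (0.53 log units; beyond the scatter).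

Compound 4 `COC(=O)NC[C@H]1CN(c2ccc(-n3cc(-c4ccccn4)cn3)c(F)c2)C(=O)O1` is not yet measured in this assay. The change is (methoxycarbonyl)amino in place of 1H-1,2,3-triazol-1-yl on a saturated chain carbon bound to a saturated ring carbon. Within the data shown here, none of the measured steps exchanges these two groups, so the three steps only show the spread that this position has produced so far, all three beyond the scatter, with compound 3 at the upper end. The entering group has no ring and one hydrogen-bond donor, a type not yet represented. A downward step of modest size is expected, a 1.8-fold lower number from compound 3 to compound 4 (0.25 log units; within the scatter), because compound 3 sits at 247000 nM and the other two variants at this position fall below it.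

Compound 4 is therefore expected at 140000 nM in this assay, with a range from 55000 nM to 330000 nM.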

Compound 4, solubility: 34100 nM
For compound 4 the middle estimate is 4.1-fold (0.61 log units) above the measured one; measured number below the stated range.
By their numbers in this assay, from the lowest: compounds 2 and 4 (each within the scatter of the next); then compound 1; then compound 3.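

Replacing 1H-1,2,3-triazol-1-yl with (methoxycarbonyl)amino keeps the heavy-atom count the same, yet this assay shows a 7.2-fold lower number from compound 3 to compound 4 (0.86 log units; beyond the scatter), so at this position that count alone does not set the number. The open-chain group with a hydrogen-bond donor joins the low end of the series, with a 1.3-fold higher number from compound 2 to compound 4 (0.10 log units; within the scatter) and a 2.7-fold lower number from compound 1 to compound 4 (0.43 log units; beyond the scatter), and across the four compounds the number does not follow group size: the 4-((methoxycarbonyl)methyl)piperidin-1-yl variant, compound 1, is the largest but stands below compound 3. No measurement offered here accounts for these steps.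

As far as these compounds go, whether the hydrogen-bond donor itself matters remains open, and a version with a methylated amide nitrogen would test this. How a primary amine or a carboxylic acid would read at this place is also unknown.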